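Swapping hydroxy for cyano: compound 3 to compound 4

The source may hold more compounds than are shown below. What is called first, only, known or untested is meant among the compounds shown, and "the series" means these compounds.

In a functional assay on PC-3 cells (Homo sapiens) for cytotoxicity, with a stated time of 48 h (on this read-out lower numbers stand for stronger inhibition and higher numbers for weaker inhibition), compound 3 (`Oc1ccc(-c2cncc(-c3cc4ccc(O)cc4[nH]3)n2)cc1`) gives 5000 nM as its reading. Two relatives built on a slightly different core were measured the same way: compound 1 (`N#Cc1ccc(-c2cncc(-c3cc4ccc(O)cc4[nH]3)c2)cc1`) gives 7000 nM as its reading and compound 2 (`CS(=O)(=O)c1ccc(-c2cncc(-c3cc4ccc(O)cc4[nH]3)c2)cc1`) gives 4000 nM as its reading. All three numbers lie within the usual scatter of one another, so compound 3 holds no clear rank among them.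

Compound 4 (`N#Cc1ccc(-c2cncc(-c3cc4ccc(O)cc4[nH]3)n2)cc1`) keeps the core of compound 3 and changes one group, cyano in place of hydroxy on an aromatic carbon, para to a large group (cyano in place of hydroxy on an aromatic carbon). Among the measured compounds shown here, only one measured step bears on this, and only loosely. On the core of compound 1, swapping cyano for methylsulfonyl gave a 1.8-fold lower number from compound 1 to compound 2 (0.24 log units; within the scatter) and so moved nothing beyond the scatter. For the measured compounds named here, no measured pair shows hydroxy giving way to cyano directly. Compound 1, which carries cyano on its own core, reads 7000 nM and that lies within the scatter of compound 3. Going by the values given here, no large step is therefore expected in this assay. The expected change is a 1.2-fold higher number from compound 3 to compound 4 (0.08 log units; within the scatter) and it would stay within the scatter. For compound 4 the estimated value is 6000 nM with an expected range from 2500 nM to 15000 nM in this test.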

Compound 4, half-maximal inhibitory concentration: 8000 nM
Beside the measured number, compound 4's estimate is 1.3-fold (0.12 log units) below it; the range from low to high includes it.
By their numbers in this assay, from the lowest: compounds 2, 3, 1 and 4 (each within the scatter of the next).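

Hydroxy giving way to cyano on the ring, para to a large group, now has a direct reading on a single core in this assay (a 1.6-fold higher number from compound 3 to compound 4 (0.20 log units; within the scatter)), where the earlier compounds offered only an indirect hint. Going from 4-hydroxyphenyl to 4-cyanophenyl takes this position from 1 hydrogen-bond donor to 0 hydrogen-bond donors, with 1 hydrogen-bond acceptor on each side, and the step stays within the scatter, so for this pair the reading does not depend measurably on which of the two groups sits here. What lies behind this small step cannot be said, as no supporting measurement is available to explain it.

Among the compounds shown here, only two groups are compared at this position on this core, so it remains open whether a very different group there, such as an amine, a carboxylic acid or a longer chain, would move the reading beyond the scatter. Going by these compounds, it is also open whether methylsulfonyl would act on this core as it did on the core of compound 1, and whether any change here could bring a clear gain in potency.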